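1,3,4-Thiadiazol-2-yl replacing 1,3-benzoxazol-2-yl on sulfur

This account rests on a few compounds, and the source may have more. Where it says the series, first, only, none or still open, it means among the compounds named here.

In a functional assay on MGC-803 cells (Homo sapiens) for antiproliferative activity, read by MTT assay, with a stated time of 48 h (on this read-out higher numbers stand for weaker inhibition and lower numbers for stronger inhibition), compound 1 (`COc1ccc(CN(C(=O)Cn2cc(COc3cc(=O)oc4ccccc34)nn2)c2cc(OC)c(OC)c(OC)c2)cc1`) gives 3660 nM, compound 2 (`COc1ccc(CN(C(=O)Cn2cc(COc3ccccc3)nn2)c2cc(OC)c(OC)c(OC)c2)cc1`) gives 12500 nM and compound 3 (`COc1ccc(CN(C(=O)Cn2cc(CSc3nc4ccccc4o3)nn2)c2cc(OC)c(OC)c(OC)c2)cc1`) gives 1850 nM. Compound 3 stands level with compound 1, as a 2.0-fold lower number from compound 1 to compound 3 (0.30 log units; within the scatter) stays within the scatter, and apart from compound 2, as a 6.8-fold lower number from compound 2 to compound 3 (0.83 log units; beyond the scatter) lies beyond it.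

Compound 4 (`COc1ccc(CN(C(=O)Cn2cc(CSc3nncs3)nn2)c2cc(OC)c(OC)c(OC)c2)cc1`) carries 1,3,4-thiadiazol-2-yl in place of 1,3-benzoxazol-2-yl on a sulfur. Going by the values given here, no measured step makes this exact change. The closest guide is compound 2, whose end group also has a single ring, and a 3.4-fold higher number from compound 1 to compound 2 (0.53 log units; beyond the scatter) points the same way. A higher number of modest size is therefore expected in this assay. The expected step is a 2.7-fold higher number from compound 3 to compound 4 (0.43 log units; beyond the scatter). For compound 4 the estimate is 5000 nM, with an expected range of 1800 nM to 14000 nM.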

Compound 4, half-maximal inhibitory concentration: 5000 nM
Compound 4: the middle estimate sits on the measured number at the digits printed, and the stated range covers the measured number.
By their numbers in this assay, from the lowest: compounds 3, 1 and 4 (each within the scatter of the next, the first and the last beyond it); then compound 2.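

In this assay, the single ring of 1,3,4-thiadiazol-2-yl on sulfur gives up part of what 1,3-benzoxazol-2-yl provides (a 2.7-fold higher number from compound 3 to compound 4 (0.43 log units; beyond the scatter)), yet (1,3,4-thiadiazol-2-yl)sulfanyl still improves on phenoxy (a 2.5-fold lower number from compound 2 to compound 4 (0.40 log units; beyond the scatter)). Single-ring end groups therefore do not all read alike at this position, and compound 4 stands level with compound 1 despite its smaller end group (a 1.4-fold higher number from compound 1 to compound 4 (0.14 log units; within the scatter)). No measured evidence explains these steps. Still open, from the compounds shown here alone, is how much of the gain over phenoxy belongs to the sulfur link, which phenylsulfanyl would test. Also open, going by these compounds, is whether an amine on the 1,3,4-thiadiazol-2-yl ring would shift the number.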